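The compounds below may be only part of what the source reports. "The series", "measured", "known", "first", "only" and "open" are said of these compounds alone.

Working notes on a small set of pyrazoline-bearing analogues tested in a functional assay on the whole organism (strain Wistar) for inhibition, with Rattus norvegicus as the target, read by paw edema, with stated times of 30 min and 60 min, at a dose of 50 mg/kg by the oral route; on this read-out higher numbers stand for more inhibition at the one dose given (going by the name of the read-out) and lower numbers for less inhibition.

Compound 1 `Fc1ccc(C2=NN(c3ccccc3)C(c3cn(-c4ccccc4)nc3-c3ccc(Cl)c(Cl)c3)C2)cc1` gives 55.7% in this assay. Compound 2 `Clc1ccc(C2=NN(c3ccccc3)C(c3cn(-c4ccccc4)nc3-c3ccc(Cl)c(Cl)c3)C2)cc1` differs from compound 1 by chloro in place of fluoro on an aromatic carbon, and compound 2 gives 53.4%; the step is a number 2.3 percentage points lower from compound 1 to compound 2 (within the scatter). Compound 3 `O=[N+]([O-])c1ccc(N2N=C(c3ccc(F)cc3)CC2c2cn(-c3ccccc3)nc2-c2ccc(Cl)c(Cl)c2)cc1` differs from compound 1 in the core by nitro in place of hydrogen on an aromatic carbon, and compound 3 gives 60.3%; the step is a number 4.6 percentage points higher from compound 1 to compound 3 (within the scatter). All three measured numbers sit within the usual scatter of one another, so no ordering among compound 1, compound 2 and compound 3 is claimed.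

Compound 4 `O=[N+]([O-])c1ccc(N2N=C(c3ccc(Cl)cc3)CC2c2cn(-c3ccccc3)nc2-c2ccc(Cl)c(Cl)c2)cc1` has not been measured. It differs from compound 3 by chloro in place of fluoro on an aromatic carbon. This is the same change already seen from compound 1 to compound 2, made here on the core that carries the nitro group of compound 3; the surroundings of the place are described in the same words for both pairs, so it is taken as the same change. For the measured compounds named here, the one measured instance, a number 2.3 percentage points lower from compound 1 to compound 2 (within the scatter), lay within the scatter, and with no second instance to compare against, the expectation for compound 4 rests on that single step alone.

The step from compound 3 to compound 4 is expected to be a number 3.3 percentage points lower from compound 3 to compound 4 (within the scatter), small and within the scatter. Compound 4 is therefore estimated to give 57% in this assay, with a range from 45% to 68% that reflects the scatter of such measurements plus the uncertainty of a single precedent.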

Compound 4, a percentage reported as inhibition, in the whole organism at one dose (the size of the read-out at that dose, not a potency): 57.3%
Beside the measured number, compound 4's estimate is 0.3 percentage points below it, within the range that was stated.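

The new step is a number 3 percentage points lower from compound 3 to compound 4 (within the scatter) and it places 4-fluorophenyl to 4-chlorophenyl on a second core in this assay, where the two instances agree: the same change on two cores in this assay, a number 2.3 percentage points lower (within the scatter) from compound 1 to compound 2 and a number 3 percentage points lower (within the scatter) from compound 3 to compound 4, 0.7 percentage points apart, within the scatter of two such steps. Compound 2 and compound 4 likewise give a second instance of nitro in place of hydrogen on an aromatic carbon, with a number 3.9 percentage points higher from compound 2 to compound 4 (within the scatter) as the new step, and this agrees with the earlier one: the same change on two cores in this assay, a number 4.6 percentage points higher (within the scatter) from compound 1 to compound 3 and a number 3.9 percentage points higher (within the scatter) from compound 2 to compound 4, 0.7 percentage points apart, within the scatter of two such steps. Neither change is seen to behave differently on the two cores across these four compounds, but all of these steps lie within the scatter, so the agreement shows neither a real effect of either change nor that a larger effect would carry from one core to another.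

The compounds shown vary only fluoro, chloro and nitro or hydrogen on aromatic carbons, so it remains open whether an amine, a carboxylic acid or a methoxy group at those places would give a step beyond the scatter. With one dose shown, it also remains open whether the same agreement between cores would hold at any other dose.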